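A Benzyl Swapped for Isobutyl: Expected Shift in Inhibition

The source may report more compounds than this note shows. Statements on the series, on what has been measured and on what is new or still open speak of the compounds shown alone.

The study reads inhibition in a functional assay on L929 cells (Mus musculus) for inhibition, read by MTT assay, with a stated time of 5 days; a higher number here means a weaker inhibitor, a lower number a stronger inhibitor. Compound 1 `COc1ccc(N(Cc2ccc([N+](=O)[O-])cc2)Cc2ccccc2OC)cc1` reaches only the limit of the assay, with compound 1 giving > 40 ug/mL. Within the data shown here, compound 2 `Cc1ccc(N(Cc2ccccc2)Cc2ccccc2)cc1` gives 11 ug/mL in this assay and is the only compound with a numerical value. The other value shown, that of compound 1, is a limit, (the limit of > 40 ug/mL in this assay, at which 1 of the 2 values shown sits). Compound 3 `Cc1ccc(N(Cc2ccccc2)CC(C)C)cc1` has not been measured. The change from compound 2 to compound 3 is isopropyl in place of phenyl on a saturated chain carbon bound to a nitrogen on an aromatic ring; cut one bond further out it reads benzyl to isobutyl. Among the measured compounds shown here, no measured pair isolates this change, so the expectation rests on compound 2 alone. A modest weakening, a 1.8-fold higher number from compound 2 to compound 3 (0.26 log units; within the scatter), is expected, at the edge of the scatter. Compound 3 is estimated at 20 ug/mL, between 8 ug/mL and 40 ug/mL, in this assay.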

Compound 3, half-maximal inhibitory concentration: 5 ug/mL
Estimate against measurement, compound 3: 4.0-fold (0.60 log units) above, and the stated range ends above it.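

In this assay, isopropyl in place of phenyl on a saturated chain carbon bound to a nitrogen on an aromatic ring gives a 2.2-fold lower number from compound 2 to compound 3 (0.34 log units; beyond the scatter). Among these compounds, this shows what the earlier compounds could not: at this place, the phenyl ring can be given up without any loss of inhibition, and a smaller group with no ring gives the stronger inhibitor of this pair. Nothing shown here accounts for the step, and the limit reached by compound 1 has no bearing on it.

The compounds shown leave open whether a longer chain, a cyclohexyl ring, an amine or a carboxylic acid at the same place would keep this gain, lose it or extend it. They also leave open whether the same exchange on the remaining benzyl group would read the same way.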